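The source may hold more compounds than are shown below. What is called first, only, known or untested is meant among the compounds shown, and "the series" means these compounds.

Measured compounds:
compound 1 `O=C1N=C(N2N=C(c3ccccc3)CC2c2ccccc2O)S/C1=C1/C(=O)Nc2ccccc21`: 4730 nM in a functional assay on cells (Cancer cell lines, Homo sapiens) for cytotoxicity, read by sulforhodamine B assay, with a stated time of 48 h; on this read-out lower numbers stand for stronger inhibition of growth and higher numbers for weaker inhibition of growth
compound 2 `COc1ccc(C2CC(c3ccccc3)=NN2C2=NC(=O)/C(=C3\C(=O)Nc4ccccc43)S2)cc1`: 6040 nM
compound 3 `O=C1N=C(N2N=C(c3ccccc3)CC2c2ccc(Cl)cc2)S/C1=C1/C(=O)Nc2ccccc21`: 6290 nM

Compound 3 is not set apart from the other two: a 1.3-fold higher number from compound 1 to compound 3 (0.12 log units; within the scatter) and a 1.0-fold higher number from compound 2 to compound 3 (0.02 log units; within the scatter) both fall within the scatter, as does a 1.3-fold higher number from compound 1 to compound 2 (0.11 log units; within the scatter). Compound 4 `Cc1ccc2c(c1)/C(=C1\SC(N3N=C(c4ccccc4)CC3c3ccc(Cl)cc3)=NC1=O)C(=O)N2` differs from compound 3 by methyl in place of hydrogen on an aromatic carbon. Going by the values given here, none of the measured steps touches this part of the shared core; each of them alters the aryl group on the saturated ring carbon, and each stays within the scatter. There is therefore no basis in the series for a shift beyond the scatter in this assay, in either direction, and a number close to that of compound 3 is expected. For compound 4 the estimate is 6000 nM (range 3000 nM to 12000 nM). The expected step is a 1.0-fold lower number from compound 3 to compound 4 (0.02 log units; within the scatter).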

Compound 4, concentration for total growth inhibition: 620 nM
For compound 4 the middle estimate is 9.7-fold (0.99 log units) above the measured one; measured number outside the range, below it.
By their numbers in this assay, from the lowest: compound 4; then compounds 1, 2 and 3 (each within the scatter of the next).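

In this assay the aromatic carbon meta to a fused ring and para to a fused ring responds strongly to substitution: methyl in place of hydrogen gives a 10-fold lower number from compound 3 to compound 4 (1.01 log units; beyond the scatter). Going by these compounds alone, the earlier steps, all on the aryl group at the saturated ring carbon, stayed within the scatter, so this position is the first to move the number beyond it. No measurement at hand explains the shift.

Open, as far as these compounds go, is whether ethyl, an amine or a carboxylic acid at this carbon would act like methyl. Also open, from the compounds shown here alone, is whether methyl gives a similar step alongside the 2-hydroxyphenyl or 4-methoxyphenyl group.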